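Trading 2-methoxyethoxy for 3-(methylsulfonyl)propoxy

The compounds below may be only part of what the source reports. "The series", "measured", "known", "first", "only" and "open" are said of these compounds alone.

In a physicochemical assay for lipophilicity, read by HPLC, in phosphate buffer, measured as octanol-water partition, at pH 7.4, tested at 100 uM (on this read-out higher numbers stand for higher lipophilicity and lower numbers for lower lipophilicity), compound 2 `COCCOc1ccc(-c2cccc(CNc3ccc(OCC(=O)O)c(F)c3)c2)c(C)c1` gives 2.23 as the higher of two numbers, while compound 1 `Cc1cc(OCCCS(C)(=O)=O)cc(C)c1-c1cccc(CNc2ccc(OCC(=O)O)c(F)c2)c1` gives 1.73 and sits lower by more than the usual scatter. Compound 3 `Cc1cc(OCCCS(C)(=O)=O)ccc1-c1cccc(CNc2ccc(OCC(=O)O)c(F)c2)c1` trades 2-methoxyethoxy for 3-(methylsulfonyl)propoxy ((methylsulfonyl)methyl in place of methoxy on a saturated chain carbon, two bonds along the chain from an oxygen on an aromatic ring). Among the compounds with values here, no measured pair shows this change alone, so the expectation leans on compound 1 (1.73), which also carries 3-(methylsulfonyl)propoxy. The expected move in this assay is downward and beyond the scatter (a number 0.78 log units lower from compound 2 to compound 3 (beyond the scatter)). For compound 3 the estimated value is 1.45 (range 1.1 to 1.8).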

Compound 3, distribution coefficient: 1.59
Compound 3: the middle estimate sits 0.14 log units below what was measured; the range from low to high includes it.
By their numbers in this assay, from the lowest: compounds 3 and 1 (each within the scatter of the next); then compound 2.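

In this assay, the swap of 2-methoxyethoxy for 3-(methylsulfonyl)propoxy now has a step of its own, with only that one place changed (a number 0.64 log units lower from compound 2 to compound 3 (beyond the scatter)). Hydrogen in place of methyl on an aromatic carbon stays within the scatter (a number 0.14 log units lower from compound 1 to compound 3 (within the scatter)), so that methyl has no readable effect on this number. No measurement at hand explains either step.

Whether the longer chain or the methylsulfonyl end accounts for the step remains open, since 3-methoxypropoxy would be needed to separate them. As far as these compounds go, what an amine at the chain end would give in this assay is also open.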